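The source may hold more compounds than are shown below. What is called first, only, known or untested is meant among the compounds shown, and "the series" means these compounds.

Within an in vivo ADME assay on the whole organism (strain Sprague-Dawley) for metabolic stability, with Rattus norvegicus as the target (on this read-out lower numbers stand for a shorter-lived compound and higher numbers for a longer-lived compound), this small series holds two measured compounds and one that still awaits testing. Compound 1, `N#Cc1cc(Cl)cc(Oc2c(Cl)ccc3c2nnn3Cc2n[nH]c3nc(N)ccc23)c1`, carries an amino group; in this assay compound 1 gives 4.7 h. Compound 2, `N#Cc1cc(Cl)cc(Oc2c(Cl)ccc3c2cnn3Cc2n[nH]c3ncccc23)c1`, has a different core and no amino group; in this assay compound 2 gives 7.6 h. Of the two numbers measured, the value of compound 2 is the one standing at the top, yet its gap to compound 1 lies within the usual scatter, so the two compounds cannot be told apart on this read-out. Compound 3, `N#Cc1cc(Cl)cc(Oc2c(Cl)ccc3c2cnn3Cc2n[nH]c3nc(N)ccc23)c1`, has not been measured. It arises from compound 2 by amino in place of hydrogen on an aromatic carbon. Within the data shown here, no measured pair isolates this change, and compound 1 and compound 2 differ in two places at once, so their values offer no clean guide to it. With the two measured values as the only anchor, the expected step is a 1.3-fold lower number from compound 2 to compound 3 (0.10 log units; within the scatter), which is expected to stay within the scatter. The estimate for compound 3 is 6 h, with a range from 3 h to 12 h.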

Compound 3, half-life in the Rattus norvegicus assay: 6.3 h
Beside the measured number, compound 3's estimate is 1.1-fold (0.02 log units) below it, and the stated range covers the measured number.
By their numbers in the Rattus norvegicus assay, from the lowest: compounds 1, 3 and 2 (each within the scatter of the next).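

Among these compounds, this pair gives the first clean reading of amino in place of hydrogen on an aromatic carbon, next to the ring nitrogen and para to a fused ring. In the Rattus norvegicus assay the change gives a 1.2-fold lower number from compound 2 to compound 3 (0.08 log units; within the scatter), so the half-life does not tell the two compounds apart, and the amino group is tolerated here without a resolvable cost on this read-out. In a physicochemical assay for solubility, at pH 2 (a higher number here means a more soluble compound, a lower number a less soluble compound), compound 2 gives < 0.1 ug/mL, which is a limit of the assay and not a number.

In the physicochemical assay compound 3 gives 40 ug/mL, a true reading, so the same single change that leaves the half-life unresolved goes with a large gain in solubility: the measured solubility of compound 2, < 0.1 ug/mL, and of compound 3, 40 ug/mL, an at least 400-fold higher number (2.60 log units; beyond the scatter)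

The compounds shown leave open whether a methylamino group, a hydroxyl group or a methoxy group in the same place would pair such solubility with an unresolved half-life. They also leave open whether the amino group has the same effect on the core of compound 1, since no partner of compound 1 without that group stands among them.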